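This account rests on a few compounds, and the source may have more. Where it says the series, first, only, none or still open, it means among the compounds named here.

Measured in an assay on NK92 cells for inhibition of interleukin-15 (Homo sapiens), read by AlphaScreen, with stated times of 30 min and 1 h; a lower number here means a stronger inhibitor, a higher number a weaker inhibitor:
compound 1 `Cn1c(Cc2nn(C)c(=O)c3ccccc23)nnc1SCCCCCCCC(=O)Nc1ccc(Cl)cc1Cl` gives 190 nM.
compound 2 `CCOC(CCn1c(Cc2nn(C)c(=O)c3ccccc23)nnc1SCCCCCCCC(=O)Nc1ccc(Cl)cc1Cl)OCC` gives 30000 nM.
compound 3 `Cn1nc(Cc2nnc(SCCCCCCCC(=O)Nc3ccc(Cl)cc3Cl)n2CCCO[Si](C)(C)C(C)(C)C)c2ccccc2c1=O` gives only a limit, > 30000 nM.

Compound 3 thus stands at the limit of > 30000 nM in this assay, at which 1 of the 3 values shown sits, which is a boundary of the assay and not a number. Compound 4 `Cn1nc(Cc2nnc(SCCCCCCCC(=O)Nc3ccc(Cl)cc3Cl)n2CCC(=O)O)c2ccccc2c1=O` differs from it by a group of 3 heavy atoms (1 carbon, 2 oxygen; no ring) in place of a group of 9 heavy atoms (7 carbon, 1 oxygen, 1 silicon; no ring), on a saturated chain carbon, two bonds along the chain from an aromatic nitrogen. For the measured compounds named here, three measured steps bear on this position: a 160-fold higher number from compound 1 to compound 2 (2.20 log units; beyond the scatter), an at least 150-fold higher number from compound 1 to compound 3 (2.19 log units; beyond the scatter), and a number no lower from compound 2 to compound 3 (the limit leaves the size open). Going by the values given here, both groups placed on that chain carbon weakened binding heavily, and no measured step shows what a smaller carboxy group does there. Compound 4 is expected to remain a weak inhibitor, with an estimated step of an at least 3.0-fold lower number from compound 3 to compound 4 (0.47 log units; beyond the scatter). The estimate for compound 4 is 10000 nM, with a range from 1500 nM to 30000 nM.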

Compound 4, half-maximal inhibitory concentration: 9500 nM
For compound 4 the middle estimate is 1.1-fold (0.02 log units) above the measured one, and the stated range covers the measured number.
By their numbers in this assay, from the lowest: compound 1; then compound 4; then compound 2.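

Compound 3 gives a limit of the assay and not a number: the limit of > 30000 nM in this assay, at which 1 of the 4 values shown sits. Carboxy at this chain carbon still gives a measurable value, which reads as an at least 3.1-fold lower number from compound 3 to compound 4 (0.49 log units; beyond the scatter) and as a 3.2-fold lower number from compound 2 to compound 4 (0.50 log units; beyond the scatter) in comparison with diethoxymethyl, so the group at the chain end does change binding. Against plain hydrogen, however, the carboxymethyl group remains costly, with a 50-fold higher number from compound 1 to compound 4 (1.70 log units; beyond the scatter) and the loss in the same direction as for compound 2.

From the compounds shown here alone, whether a shorter chain ending in an amine or a hydroxy group would come closer to compound 1 stays open. So does the effect of a methyl ester or primary amide in place of carboxy.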